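Aryl amide change at the assay limit

The source may report more compounds than this note shows. Statements on the series, on what has been measured and on what is new or still open speak of the compounds shown alone.

- compound 1 `Nc1ccccc1NC(=O)CCCNCC(=O)Nc1ccc(Br)cc1` gives > 100000 nM (a limit)
- compound 2 `Nc1ccccc1NC(=O)CCCNCC(=O)Nc1cc(Cl)ccc1Cl` gives > 100000 nM (a limit)

In a functional assay on HCT-116 cells (Homo sapiens) for inhibition, read by MTT assay, with a stated time of 2 days (a higher number here means that more compound is tolerated, a lower number that less compound is tolerated), compound 2 gives > 100000 nM as a limit, not a number. Both values shown are limits (the limit of > 100000 nM in this assay, at which 2 of the 2 values shown sit). Going by the values given here, the one measured step (a step that the two limits leave unreadable from compound 1 to compound 2) has no readable size. Compound 3 (`COc1ccc(NC(=O)CNCCCC(=O)Nc2ccccc2N)cc1`) carries 4-methoxyphenyl in place of 2,5-dichlorophenyl on an amide-type nitrogen. Among the compounds with values here, with that unreadable step as the only precedent, no change beyond the scatter is expected in this assay in either direction. The estimated step (a number no higher from compound 2 to compound 3 (the limit leaves the size open)) may itself prove unreadable. For compound 3 the expected value is 100000 nM (estimated range 30000 nM to 200000 nM).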

Compound 3, concentration lethal to 50% of the cells: > 100000 nM
Compound 3: only a limit was reported; the forecaster's own chance of this, stated with the estimate: 70%; the middle value lies on the limit itself.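

Compound 3 in this assay gives > 100000 nM, a limit and not a number, so no step among compound 1, compound 2 and compound 3 can be read: the limit of > 100000 nM in this assay, at which 3 of the 3 values shown sit.

The compounds shown leave open whether these aryl groups on the amide-type nitrogen differ at all.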